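This account rests on a few compounds, and the source may have more. Where it says the series, first, only, none or still open, it means among the compounds named here.

Compound 1, `N#Cc1ccc(NC(=S)N/N=C/c2ccc3ccccc3n2)cc1`, gives 15600 nM in a functional assay on HT-29 cells (Homo sapiens) for antiproliferative activity, read by sulforhodamine B assay, with a stated time of 72 h; a higher number here means a weaker inhibitor, a lower number a stronger inhibitor. Compound 2, `Fc1ccccc1NC(=S)N/N=C/c1ccc2ccccc2n1`, reaches only a limit of the assay, > 100000 nM, and this is the limit of > 100000 nM in this assay, at which 1 of the 2 values shown sits. Compound 3, `FC(F)(F)c1ccc(NC(=S)N/N=C/c2ccc3ccccc3n2)cc1`, has not been measured.

Among the two measured compounds, compound 1 holds the only actual number; the other value is a limit rather than a measurement. Among the compounds with values here, the one measured step runs an at least 6.4-fold higher number from compound 1 to compound 2 (0.80 log units; beyond the scatter), with 2-fluorophenyl in place of 4-cyanophenyl on an amide-type nitrogen, so swapping the aryl group on the thiourea nitrogen cost at least a modest amount of activity.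

Compound 3 differs from compound 1 by trifluoromethyl in place of cyano on an aromatic carbon. The ring and its attachment to the shared core are kept; only the group in the same place changes. The measured step touches the same aryl group but replaces it wholesale, so it bears on this change only indirectly. The expectation for a 1.6-fold higher number from compound 1 to compound 3 (0.20 log units; within the scatter) is therefore a step within the scatter or somewhat weaker, not a large shift. Compound 3 is estimated at 25000 nM, between 8000 nM and 80000 nM.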

Compound 3, half-maximal inhibitory concentration: 63900 nM
Beside the measured number, compound 3's estimate is 2.6-fold (0.41 log units) below it, within the range that was stated.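

In this assay, trifluoromethyl in place of cyano gives a 4.1-fold higher number from compound 1 to compound 3 (0.61 log units; beyond the scatter), which shows that this place on the aromatic ring, para to a large group, responds to the exchange of a single group while the ring itself stays. The earlier step replaced the whole aryl group and ended at a limit of the assay, so it gave only a bound, whereas this step has a real number at both ends and its size can be read directly. Of the two groups compared at this place, the nitrile of compound 1 gives the lower number, but nothing shown here explains why the trifluoromethyl group costs activity.

The compounds shown leave open whether an amine, a carboxylic acid, a methoxy group or a longer chain at this place would match or improve on compound 1. They also leave open how the ring with only hydrogen at this place would compare, so two groups fix no trend for this position.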